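The source may hold more compounds than are shown below. What is called first, only, known or untested is meant among the compounds shown, and "the series" means these compounds.

Measured so far in a functional assay (Homo sapiens) for antiproliferative activity; a higher number here means a weaker inhibitor of growth, a lower number a stronger inhibitor of growth 

- compound 1 `Cc1cn2c(/C=N/NC(=N)N)c(-c3cccnc3)nc2s1` gives 4790 nM
- compound 2 `N=C(N)N/N=C/c1c(-c2cc([N+](=O)[O-])c(Cl)cc2Cl)nc2sc(Cl)cn12` gives 3550 nM
- compound 3 `N=C(N)N/N=C/c1c(-c2ccccn2)nc2sc(Cl)cn12` gives 4370 nM

All three values lie within the scatter of each other, so the set shows no order among them. Compound 3 gives 4370 nM and stands within the scatter of both compound 1 and compound 2.

Compound 4 `N=C(N)N/N=C/c1c(-c2cccnc2)nc2sc(Cl)cn12` has not yet been measured. It differs from compound 3 by having pyridin-3-yl in place of pyridin-2-yl on an aromatic carbon. For the measured compounds named here, no pair of measured compounds differs in one place only, so the series offers no direct precedent for this change.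

The expectation rests on two values. Compound 3 gives 4370 nM with pyridin-2-yl, and compound 1, which also carries pyridin-3-yl, gives 4790 nM on its own core. On that basis, no step beyond the scatter is expected in this assay and no direction can be favoured. The expected change is a 1.0-fold lower number from compound 3 to compound 4 (0.02 log units; within the scatter) and stays within the scatter. For compound 4 the estimated value is 4200 nM with an expected range of 2200 nM to 8000 nM in this assay.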

Compound 4, concentration for 50% growth inhibition: 13800 nM
Compound 4: the middle estimate sits 3.3-fold (0.52 log units) below what was measured; measured number outside the range, above it.
By their numbers in this assay, from the lowest: compounds 2, 3 and 1 (each within the scatter of the next); then compound 4.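

In this assay, pyridin-3-yl in place of pyridin-2-yl on this aromatic carbon gives a 3.2-fold higher number from compound 3 to compound 4 (0.50 log units; beyond the scatter) even though the two groups have the same atoms, so the ring attachment of the pyridine alone can shift the number beyond the scatter at this position. For the compounds shown here, this is the first single-place step, and the earlier values, all within the scatter of each other, gave no sign of it. The series also now shows that the other ring substituent counts with pyridin-3-yl held constant: chloro in place of methyl on an aromatic carbon gives a 2.9-fold higher number from compound 1 to compound 4 (0.46 log units; beyond the scatter) as the second step beyond the scatter. No measurement available here accounts for either step.

Whether the pyridin-2-yl to pyridin-3-yl step is the same size on the methyl-bearing core remains open, since only the chloro-bearing core has both groups among the compounds shown. Equally open, going by these compounds, is how pyridin-4-yl or plain phenyl would read at this position, and so whether the step follows the place of the ring nitrogen or is specific to this pair.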